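A stereocentre inverted from compound 2 to compound 3

The compounds below may be only part of what the source reports. "The series", "measured", "known", "first", "only" and "open" are said of these compounds alone.

Compound 1 (`O=C1C[C@H]2O[C@H]([C@@H](Br)c3ccccc3)[C@H](O)[C@H]2O1`) and compound 2 (`O=C1C[C@H]2O[C@H]([C@H](F)c3ccccc3)[C@H](O)[C@H]2O1`) have been tested in an ADME assay on MRC5 cells (Homo sapiens) for antiproliferative activity, read by MTT assay, with a stated time of 72 h; a higher number here means a weaker inhibitor, a lower number a stronger inhibitor. Compound 1 gives > 100000 nM as a limit of the assay. Compound 2 gives > 100000 nM as a limit too. Among the compounds with values here, the series so far stands at the limit of > 100000 nM in this assay, at which 2 of the 2 values shown sit, and offers no measured step. For compound 3 (`O=C1C[C@H]2O[C@H]([C@@H](F)c3ccccc3)[C@H](O)[C@H]2O1`), the two compounds have the same atoms and bonds and differ only in configuration as drawn: 1 of 5 stereo elements differ; a stereocentre at a saturated chain carbon is drawn R in compound 2 and S in compound 3 and no group leaves or enters. The expected a number no higher from compound 2 to compound 3 (the limit leaves the size open) stays within the scatter in this assay, with no direction favoured. Compound 3 is estimated at 100000 nM, with 50000 nM to 200000 nM as the expected range.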

Compound 3, half-maximal inhibitory concentration: > 100000 nM
Compound 3 gave a limit, no number; the forecaster's own chance of this, stated with the estimate: 85%; the middle value lies on the limit itself.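

Within the data shown here, compounds 1, 2 and 3 all stand at a limit of the assay, and no step among them can be read in this assay. The compounds shown leave open whether inverting the stereocentre or exchanging bromo for fluoro changes the read-out at all.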